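Furan-3-yl to thiophen-3-yl in an antiproliferative series

A few compounds are considered here, and "the series" means these few. Any claim that something is new, unique, unknown or untested is made for them only; others in the source may bear on it.

In a functional assay on HCT-116 cells (Homo sapiens) for antiproliferative activity, read by sulforhodamine B assay (a higher number here means a weaker inhibitor, a lower number a stronger inhibitor), compound 3 `O=C1NC(=O)c2ccc(-c3ccoc3)cc2/C1=C/Nc1ccc(CN2CCCCC2)cc1` gives 1900 nM, within the scatter of both compound 1 `O=C1NC(=O)c2ccc(I)cc2/C1=C/Nc1ccc(CN2CCCCC2)cc1` at 2700 nM and compound 2 `CN1CCN(c2ccc(N/C=C3\C(=O)NC(=O)c4ccc(-c5ccsc5)cc43)cc2)CC1` at 1400 nM. The unmeasured compound 4 `O=C1NC(=O)c2ccc(-c3ccsc3)cc2/C1=C/Nc1ccc(CN2CCCCC2)cc1` has thiophen-3-yl in place of furan-3-yl on an aromatic carbon. For the measured compounds named here, the only measured step at this place is a 1.4-fold lower number from compound 1 to compound 3 (0.15 log units; within the scatter), and it stays within the scatter even though iodo is the group replaced. Compound 2, which also carries thiophen-3-yl but differs elsewhere, stands at 1400 nM. The estimated step is a 1.1-fold lower number from compound 3 to compound 4 (0.02 log units; within the scatter), and nothing beyond the scatter is expected. Compound 4 is expected at 1800 nM, with an estimated range of 1000 nM to 3200 nM.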

Compound 4, half-maximal inhibitory concentration: 1000 nM
Compound 4: the middle estimate sits 1.8-fold (0.26 log units) above what was measured; low and high end bracket the measured number.
By their numbers in this assay, from the lowest: compounds 4, 2, 3 and 1 (each within the scatter of the next, the first and the last beyond it).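

In this assay, thiophen-3-yl in place of furan-3-yl (a 1.9-fold lower number from compound 3 to compound 4 (0.28 log units; within the scatter)) does not separate the two rings at this position. Thiophen-3-yl in place of iodo (a 2.7-fold lower number from compound 1 to compound 4 (0.43 log units; beyond the scatter)) gives the first step here to pass the scatter, though it is modest. With thiophen-3-yl held, (piperidin-1-yl)methyl in place of 4-methylpiperazin-1-yl (a 1.4-fold lower number from compound 2 to compound 4 (0.15 log units; within the scatter)) also leaves the two compounds unseparated.

As far as these compounds go, whether a phenyl or pyridin-3-yl ring at this place would keep the difference from iodo remains open. Nothing shown explains that difference.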